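The source may hold more compounds than are shown below. What is called first, only, known or untested is meant among the compounds shown, and "the series" means these compounds.

Working notes on the series. Compound 1 `Cc1nc(N2CCC(N3CCOC3=O)CC2)nc2ccc(NC(=O)/C=C/c3ccc(OC(F)(F)F)cc3)cc12` and compound 2 `Cc1nc(N2CCC(N3CCNC3=O)CC2)nc2ccc(NC(=O)/C=C/c3ccc(OC(F)(F)F)cc3)cc12` share one core and differ only in the five-membered ring on the saturated ring carbon. In an ADME assay on microsomes from liver (Homo sapiens) for metabolic stability, with a stated time of 30 min (on this read-out higher numbers stand for a more stable compound and lower numbers for a less stable compound), compound 1 gives 85% and compound 2 gives 83%; the step of a number 2 percentage points lower from compound 1 to compound 2 (within the scatter) shows that swapping one five-membered ring for another at this position left the read-out unchanged within the scatter. Compound 3 `Cc1nc(N2CCC(N3C(=O)CCC3=O)CC2)nc2ccc(NC(=O)/C=C/c3ccc(OC(F)(F)F)cc3)cc12` carries a 2,5-dioxopyrrolidin-1-yl at the same carbon; in this assay compound 3 is recorded as "not determined" (no result reported), so it stands without a number. Compound 4 `Cc1nc(N2CCC(N3CCN(C)C3=O)CC2)nc2ccc(NC(=O)/C=C/c3ccc(OC(F)(F)F)cc3)cc12` differs from compound 3 by 3-methyl-2-oxoimidazolidin-1-yl in place of 2,5-dioxopyrrolidin-1-yl on a saturated ring carbon. Among the compounds with values here, no measured step covers this exact change; the only step that bears on it, from compound 1 to compound 2, is within the scatter, and compound 4 differs from compound 2 only by the methyl of its 3-methyl-2-oxoimidazolidin-1-yl. A value close to those of compound 1 and compound 2 is therefore expected, with no step beyond the scatter pointing elsewhere. For compound 4 the estimate in this assay is 80%, ranging from 65% to 92%.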

Compound 4, percent of the compound remaining: 33%
Compound 4: the middle estimate sits 47 percentage points above what was measured; the whole stated range lies above it.
By their numbers in this assay, from the lowest: compound 4; then compounds 2 and 1 (each within the scatter of the next).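

In this assay, within the data shown here, this position is not as indifferent as the first pair suggested: a number 50 percentage points lower from compound 2 to compound 4 (beyond the scatter), and the only change there is methyl in place of hydrogen on an amide-type nitrogen in a ring. The step of a number 52 percentage points lower from compound 1 to compound 4 (beyond the scatter) is just as large, whereas the exchange of one unmethylated ring for the other, a number 2 percentage points lower from compound 1 to compound 2 (within the scatter), stays within the scatter, so among compounds 1, 2 and 4 only the ring bearing the methyl stands apart. Nothing available accounts for this drop.

Open, as far as these compounds go, is whether a longer chain such as ethyl, or a chain ending in a carboxylic acid, on that same nitrogen would read like the methyl or like the hydrogen. Also open, from the compounds shown here alone, is how a simple amine on the saturated ring carbon, in place of the five-membered ring, would read.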